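The source may hold more compounds than are shown below. What is called first, only, known or untested is meant among the compounds shown, and "the series" means these compounds.

Three compounds were measured in a functional assay on SMMC-7721 cells (Homo sapiens) for cytotoxicity, read by MTT assay, with a stated time of 24 h; a lower number here means a stronger inhibitor, a higher number a weaker inhibitor:

compound 1, `O=C1/C(=C/c2cccnc2)CN(S(=O)(=O)c2ccc(Cl)cc2)C/C1=C\c1ccccc1F`, gave 16100 nM;
compound 2, `O=C1/C(=C/c2cccnc2)CN(S(=O)(=O)c2ccc(Br)cc2)C/C1=C\c1ccccc1F`, gave 9100 nM;
compound 3, `O=C1/C(=C/c2ccncc2)CN(S(=O)(=O)c2ccc(Cl)cc2)C/C1=C\c1ccccc1F`, gave 9600 nM.

Compound 2 differs from compound 1 by bromo in place of chloro on an aromatic carbon, a change that produced a 1.8-fold lower number from compound 1 to compound 2 (0.25 log units; within the scatter). Compound 3 differs from compound 1 in its core by pyridin-4-yl in place of pyridin-3-yl on a double-bonded chain carbon bound to a double-bonded ring carbon, which produced a 1.7-fold lower number from compound 1 to compound 3 (0.22 log units; within the scatter). Compound 4, `O=C1/C(=C/c2ccncc2)CN(S(=O)(=O)c2ccc(Br)cc2)C/C1=C\c1ccccc1F`, is not yet measured; it differs from compound 3 by bromo in place of chloro on an aromatic carbon, at a place described in the same words as for compound 1 and compound 2, so this is the same change. Because the earlier step was a 1.8-fold lower number from compound 1 to compound 2 (0.25 log units; within the scatter), compound 4 is expected to show a step of a 1.5-fold lower number from compound 3 to compound 4 (0.17 log units; within the scatter), a shift of about that size that again lies within the usual scatter. Compound 4 is therefore estimated at 6500 nM, likely between 3000 nM and 14000 nM.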

Compound 4, half-maximal inhibitory concentration: 12600 nM
Beside the measured number, compound 4's estimate is 1.9-fold (0.29 log units) below it, within the range that was stated.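

In this assay, bromo in place of chloro on the core of compound 3 gave a 1.3-fold higher number from compound 3 to compound 4 (0.12 log units; within the scatter), and set beside the earlier step it shows no difference beyond the scatter: the same change on two cores in this assay, a 1.8-fold lower number (0.25 log units; within the scatter) from compound 1 to compound 2 and a 1.3-fold higher number (0.12 log units; within the scatter) from compound 3 to compound 4, 2.3-fold (0.37 log units) apart, within the scatter of two such steps
Pyridin-4-yl in place of pyridin-3-yl, carried to the bromo compounds, gave a 1.4-fold higher number from compound 2 to compound 4 (0.14 log units; within the scatter), and the same holds: the same change on two cores in this assay, a 1.7-fold lower number (0.22 log units; within the scatter) from compound 1 to compound 3 and a 1.4-fold higher number (0.14 log units; within the scatter) from compound 2 to compound 4, 2.3-fold (0.37 log units) apart, within the scatter of two such steps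
The four compounds thus fit each change carrying from one core to the other as a small step, but every step lies within the scatter, so they do not show that either change has a real effect on either core.

The compounds shown leave open how an amine or a carboxylic acid in place of the chloro or bromo would read in this assay. They also leave open whether a pyridin-2-yl group would differ from the two pyridinyl groups shown.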